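This account rests on a few compounds, and the source may have more. Where it says the series, first, only, none or still open, it means among the compounds named here.

Measured so far:
- compound 1, `CNc1nc(NC)nc(NC2(C#N)CCCCC2)n1`: 210 mL/min/kg
- compound 2, `CCC(C)(C#N)Nc1nc(NC)nc(-n2cncn2)n1`: 32 mL/min/kg
- compound 3, `CNc1nc(NC2(C#N)CCCCC2)nc(SC)n1`: 579 mL/min/kg

In an ADME assay on microsomes from liver (Rattus norvegicus) for metabolic stability (a higher number here means faster removal of the compound, a lower number slower removal), compound 1 gives 210 mL/min/kg, which places it second highest of the three numbers. Its nearest neighbour is compound 3, where the change a 2.8-fold higher number from compound 1 to compound 3 (0.44 log units; beyond the scatter) lies beyond the scatter. For the measured compounds named here, compound 2, with 32 mL/min/kg, is the furthest away, and no single-point step connects it to compound 1, so only its two values can be compared.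

Compound 4, `CNc1nc(NC2(C#N)CCCCC2)nc(N2CCCC2)n1`, differs from compound 1 in one place: pyrrolidin-1-yl in place of methylamino on an aromatic carbon. Going by the values given here, the methylamino group that leaves is the same one that was exchanged for methylsulfanyl on the way to compound 3, so the step from compound 1 to compound 3 is the only measured change that bears on this one, and it was a modest rise. Pyrrolidin-1-yl is a different replacement, and no measured pair shows its effect here. A modest rise in this assay is therefore the expectation, though a result within the scatter of compound 1 cannot be ruled out. For compound 4 the expected step is a 1.5-fold higher number from compound 1 to compound 4 (0.18 log units; within the scatter), giving an estimate of 320 mL/min/kg with a range from 130 mL/min/kg to 800 mL/min/kg.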

Compound 4, clearance: > 276 mL/min/kg
Compound 4 gave a limit, no number; the forecaster's own chance of this, stated with the estimate: 2%; the middle value does not contradict the limit.
By their numbers in this assay, from the lowest: compound 2; then compound 1; then compound 3.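

In this assay compound 4 gives a limit and not a number: > 276 mL/min/kg. The step reads an at least 1.3-fold higher number from compound 1 to compound 4 (0.11 log units; that floor lies within the scatter), so pyrrolidin-1-yl, which has no hydrogen-bond donor where methylamino has one, gives no sign of lowering the clearance at this position opposite the ring nitrogen, although the floor of that step does not establish a rise. Compound 4 is thus a second replacement of methylamino at this place, after the methylsulfanyl of compound 3, and neither one gives a lower number than compound 1, but how far compound 4 rises stays hidden and the step between compound 3 and compound 4 cannot be read because the result is capped: the limit of > 276 mL/min/kg in this assay, at which 1 of the 4 values shown sits.

As far as these compounds go, what a plain amino group or a morpholine ring would do in place of methylamino at this position remains open. So does the question of whether any replacement at this place can bring the clearance below that of compound 1, since both replacements shown leave that question unanswered.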